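The source may hold more compounds than are shown below. What is called first, only, known or untested is meant among the compounds shown, and "the series" means these compounds.

Compound 1 `Fc1ccccc1CSc1nnc(-c2cnccn2)s1` and compound 2 `Clc1ccccc1CSc1nnc(-c2cnccn2)s1` share one core and differ in a single place. In a functional assay on HeLa cells (Homo sapiens) for antiproliferative activity, read by MTT assay, with a stated time of 48 h (on this read-out higher numbers stand for weaker inhibition and lower numbers for stronger inhibition), compound 1 gives 32700 nM and compound 2 gives 28900 nM; the two differ by chloro in place of fluoro on an aromatic carbon. Compound 3 `Fc1ccc(CSc2nnc(-c3cnccn3)n2-c2ccccc2)cc1` carries another core, and how its core differs from that of compound 1 is not broken down here. In this assay compound 3 gives 7300 nM, the lowest of the three numbers. Compound 4 `Clc1ccc(CSc2nnc(-c3cnccn3)n2-c2ccccc2)cc1` remains to be measured. It differs from compound 3 by chloro in place of fluoro on an aromatic carbon. This is the same kind of change as the earlier one, though here the place is para to a large group, whereas earlier it was ortho to a large group. Because the earlier step was a 1.1-fold lower number from compound 1 to compound 2 (0.05 log units; within the scatter), the step of a 1.1-fold lower number from compound 3 to compound 4 (0.05 log units; within the scatter) is expected to be of similar size. Compound 4 is therefore expected to give about 6500 nM. Its value is estimated to fall between 3000 nM and 15000 nM.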

Compound 4, half-maximal inhibitory concentration: > 50000 nM
Compound 4: no number, only a limit (the forecaster's own chance of this, stated with the estimate: 5%); at least 7.6-fold (0.88 log units) between middle value and limit.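

In this assay, on these data alone, the change gives an at least 6.8-fold higher number from compound 3 to compound 4 (0.83 log units; beyond the scatter), so chloro in place of fluoro does not carry over with the same effect from the core of compound 1 to the core of compound 3: the same change on two cores in this assay, a 1.1-fold lower number (0.05 log units; within the scatter) from compound 1 to compound 2 and an at least 6.8-fold higher number (0.83 log units; beyond the scatter) from compound 3 to compound 4, at least 7.7-fold (0.88 log units) apart, beyond the scatter of two such steps Compound 4 gives > 50000 nM, which is a limit of the assay and not a number, so the full size of the step stays unknown: the limit of > 50000 nM in this assay, at which 1 of the 4 values shown sits. The two pairs differ both in core and in where the change sits, and these data cannot separate those two differences.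

The compounds shown leave open whether methyl, methoxy or bromo in that place would give a number near that of compound 3 or reach the limit. They also leave open how the core of compound 1 would respond to the same groups.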